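A few compounds are considered here, and "the series" means these few. Any claim that something is new, unique, unknown or untested is made for them only; others in the source may bear on it.

Compound 3 `CCC(=O)N1CCN(Cc2nc3ccccc3n2Cc2cccc(C)c2)CC1` carries a propanoyl group on the ring nitrogen of the piperazine and gives 85.1% in an assay on isolated protein for inhibition of aldehyde dehydrogenase 1A1 (Homo sapiens), read by spectrophotometry, tested at 10 uM (a higher number here means more inhibition at the concentration tested (going by the name of the read-out), a lower number less inhibition), the highest of the three numbers measured. Its nearest neighbour is compound 1 `CC(=O)N1CCN(Cc2nc3ccccc3n2Cc2cccc(C)c2)CC1`, which in this assay gives 70.3%; the step of a number 14.8 percentage points higher from compound 1 to compound 3 (beyond the scatter) lies beyond the scatter. Furthest away is compound 2 `Cc1cccc(Cn2c(CN3CCN(C(=O)c4ccncc4)CC3)nc3ccccc32)c1`, which gives 20.6% in this assay.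

Compound 4 `Cc1cccc(Cn2c(CN3CCN(C(=O)c4cccs4)CC3)nc3ccccc32)c1` differs from compound 3 by thiophen-2-yl in place of ethyl on a carbonyl carbon. Among the compounds with values here, two measured steps bear on this: a number 49.7 percentage points lower from compound 1 to compound 2 (beyond the scatter) and a number 64.5 percentage points higher from compound 2 to compound 3 (beyond the scatter), both large, both showing that a pyridin-4-yl group on the carbonyl carbon goes with far less inhibition than a methyl or ethyl group there. A thiophen-2-yl group is not a pyridin-4-yl group, so the size of the effect is uncertain, but a drop beyond the scatter is expected. Compound 4 is therefore expected to show a number 45.1 percentage points lower from compound 3 to compound 4 (beyond the scatter) and to give about 40% in this assay, within a range from 15% to 65%.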

Compound 4, a percentage reported as inhibition, at one concentration (the size of the read-out at that concentration, not a potency): 60.8%
For compound 4 the middle estimate is 20.8 percentage points below the measured one; low and high end bracket the measured number.
By their numbers in this assay, from the lowest: compound 2; then compounds 4 and 1 (each within the scatter of the next); then compound 3.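

In this assay the two aromatic rings on the carbonyl carbon part widely, with a number 40.2 percentage points higher from compound 2 to compound 4 (beyond the scatter) as the step between them, so the loss seen with pyridin-4-yl is not shared by every ring placed there. The thiophen-2-yl group is still set apart from the ethyl group, with a number 24.3 percentage points lower from compound 3 to compound 4 (beyond the scatter) on that side, whereas the comparison with the methyl group gives a number 9.5 percentage points lower from compound 1 to compound 4 (within the scatter) and so separates neither compound from the other. Nothing measured here explains why these groups on the carbonyl carbon differ.

On these data alone, whether a phenyl, furan-2-yl or pyridin-3-yl group on the carbonyl carbon would stand with thiophen-2-yl or with pyridin-4-yl remains open. So does whether a longer chain, such as a propyl group in place of the ethyl group, would keep the level of compound 3 in this assay.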